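The source may hold more compounds than are shown below. What is called first, only, known or untested is meant among the compounds shown, and "the series" means these compounds.

In a functional assay on MIA PaCa-2 cells (Homo sapiens) for inhibition (on this read-out lower numbers stand for stronger inhibition and higher numbers for weaker inhibition), compound 1 `CCC(C)C(NC(=O)NO)C(=O)NC(c1ccccc1)c1ccccc1` gives 63800 nM. Compound 2 `CCC(C)C1NC(=O)N(C2CCCC2)C1=O` gives only a limit in this assay, > 100000 nM. That value is the limit of > 100000 nM in this assay, at which 1 of the 2 values shown sits, so for compound 2 no number is known, only that it lies at the limit of the assay. Compound 3 `CC(C)C1NC(=O)N(C2CCCC2)C1=O` differs from compound 2 by hydrogen in place of methyl on a saturated chain carbon, two bonds along the chain from a saturated ring carbon. Going by the values given here, no measured step between two compounds sharing the core of compound 2 is available, and the change is a small one, so the expected step in this assay is none beyond the scatter. The expected step is a step that the limit leaves unreadable from compound 2 to compound 3. Compound 3 is therefore estimated at 150000 nM, with a range from 50000 nM to 500000 nM, and it is expected most likely to be reported again only as a limit.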

Compound 3, half-maximal inhibitory concentration: > 100000 nM
Compound 3 was reported as a limit; the forecaster's own chance of this, stated with the estimate: 85%; the middle value does not contradict the limit.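

Compound 2 and compound 3 are both reported only as limits in this assay, so no step can be read between them: the limit of > 100000 nM in this assay, at which 2 of the 3 values shown sit.

The compounds shown leave open how strongly either compound inhibits, and whether hydrogen in place of methyl at this place changes inhibition at all.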